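The source may hold more compounds than are shown below. What is called first, only, known or untested is meant among the compounds shown, and "the series" means these compounds.

Compound 1 (`CCCCCCCCCCCCCCCCC(=O)c1csc(-c2ccccc2)n1`): > 20000 nM (a limit)
Compound 2 (`CCc1ccc(-c2nc(C(=O)c3cc(OC)c(OC)c(OC)c3)cs2)cc1`): 27 nM

Going by the values given here, in a functional assay on PC-3 cells (Homo sapiens) for cytotoxicity, read by sulforhodamine B assay, with a stated time of 48 h (on this read-out lower numbers stand for stronger inhibition and higher numbers for weaker inhibition), compound 2 gives 27 nM, the only actual number so far. Compound 1 reads > 20000 nM, which is a limit of the measurement. Compound 3 (`COC(=O)c1ccc(-c2nc(C(=O)c3cc(OC)c(OC)c(OC)c3)cs2)cc1`) has methoxycarbonyl in place of ethyl on an aromatic carbon, para to a large group (methoxycarbonyl in place of ethyl on an aromatic carbon). Among the compounds with values here, no measured pair isolates this change. A moderate weakening in this assay is nevertheless expected, an estimated 5.6-fold higher number from compound 2 to compound 3 (0.74 log units; beyond the scatter). For compound 3 the expected value is 150 nM, with an estimated range from 35 nM to 800 nM.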

Compound 3, half-maximal inhibitory concentration: > 20000 nM
Compound 3 gave a limit, no number (the forecaster's own chance of this, stated with the estimate: 5%); middle value at least 130-fold (2.12 log units) from the limit.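

In this assay, going by these compounds alone, the aromatic carbon para to a large group proves highly sensitive to what it carries: methoxycarbonyl in place of ethyl gives an at least 740-fold higher number from compound 2 to compound 3 (2.86 log units; beyond the scatter) and is the first change in a single place that can be read. Compound 3 stands at a limit and not at a number, so this step gives only a minimum: the limit of > 20000 nM in this assay, at which 2 of the 3 values shown sit. The compounds shown leave open whether an amine, a carboxylic acid or a longer chain at this position would read nearer to compound 2 or to compound 3.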